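A methyl on the ring nitrogen of compound 2

A few compounds are considered here, and "the series" means these few. Any claim that something is new, unique, unknown or untested is made for them only; others in the source may bear on it.

Compound 1 `Cc1n[nH]c(-c2ccccc2NCC2=NCCN2)n1`: < 5020 nM
Compound 2 `c1ccc(-c2cn[nH]c2)c(NCC2=NCCN2)c1`: 79.4 nM

Within the data shown here, in an in vitro functional assay on cells (Fibroblast) for agonist activity at Alpha-1B adrenergic receptor (Homo sapiens) (a higher number here means that more compound is needed for the effect, a lower number that less compound is needed), compound 2 gives 79.4 nM, the only reading that is a number. Compound 1 gives < 5020 nM, which is a limit of the assay and not a number. The size of the step that the limit leaves unreadable from compound 1 to compound 2 therefore cannot be read because of the limit of < 5020 nM in this assay, at which 1 of the 2 values shown sits.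

Compound 3 `Cn1cc(-c2ccccc2NCC2=NCCN2)cn1` differs from compound 2 by methyl in place of hydrogen on an aromatic nitrogen. Among the measured compounds shown here, none of the measured steps bears on this change: the only measured step swaps one whole five-membered ring for another, and its size is unreadable, so it gives no guide to adding a methyl on a ring nitrogen. For the measured compounds named here, with no comparable step available, the expectation for this assay rests on compound 2 alone, and no shift beyond the usual scatter is assumed in either direction.

Compound 3 is therefore expected to give about 100 nM, within a range from 30 nM to 400 nM. This estimate means a step of a 1.3-fold higher number from compound 2 to compound 3 (0.10 log units; within the scatter) that is expected to sit within the scatter of repeated measurements.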

Compound 3, half-maximal effective concentration: < 100000 nM
Compound 3: only a limit was reported; the forecaster's own chance of this, stated with the estimate: 5%; the middle value does not contradict the limit.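

Compound 3 gives < 100000 nM in this assay, which is a limit of the assay and not a number. The steps to compound 3 from compound 2 and from compound 1 therefore cannot be read. The compounds shown leave open whether methyl in place of hydrogen on the aromatic nitrogen of compound 2 changes the reading, in which direction and by how much.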